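This account rests on a few compounds, and the source may have more. Where it says the series, first, only, none or still open, it means among the compounds named here.

Compound 1 `O=S(=O)(CC1=NCCO1)c1n[nH]cc1-c1ccc(Cl)cc1` is reported in a functional assay, read by Griess assay, with a stated time of 150 min, tested at 75 ug/mL (a lower number here means a weaker effect, a higher number a stronger effect of the compound at the concentration tested), as "not active" (no number reported), so no single number stands for it on this read-out. Among the measured compounds shown here, compound 2 `O=S(=O)(CC1=NCCO1)c1n[nH]cc1-c1ccccc1` gives 54.7% in this assay; no step between the two has been computed, so the two results are only set side by side. Compound 3 `O=S(=O)(CC1=NCCS1)c1n[nH]cc1-c1ccc(Cl)cc1` differs from compound 1 by a group of 5 heavy atoms (3 carbon, 1 nitrogen, 1 sulfur; one five-membered non-aromatic ring with 2 hetero atoms) in place of a group of 5 heavy atoms (3 carbon, 1 nitrogen, 1 oxygen; one five-membered non-aromatic ring with 2 hetero atoms), on a saturated chain carbon bound to a sulfonyl sulfur. For the measured compounds named here, no measured step covers this kind of change; with compound 1 reported as "not active" (no number reported), a shift of no more than the usual scatter in this assay is expected, in either direction. Compound 3 is estimated at 15%, with a range from 0% to 40%.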

Compound 3, a percentage reported as activity, at one concentration (the size of the read-out at that concentration, not a potency): "not active" (no number reported)
The entry for compound 3 holds no number, so the estimate cannot be set against anything.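

In this assay compound 1 and compound 3 both carry no number, so no step can be read between them. Left open is whether exchanging the oxygen-containing ring for the sulfur-containing ring changes this read-out at all. No evidence bears on this result.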